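The source may report more compounds than this note shows. Statements on the series, on what has been measured and on what is new or still open speak of the compounds shown alone.

compound 1 `COc1cc(C2=NN(C(=O)c3ccccc3)C(c3ccc(Cl)cc3)C2)ccc1O` — 6000000 nM
compound 2 `COc1cc(C2=NN(C(=S)Nc3ccccc3)C(c3ccc(Cl)cc3)C2)ccc1O` — 4770000 nM

Of the compounds shown here, two have so far been measured in an assay on isolated protein for inhibition of Amine oxidase [flavin-containing] B (Homo sapiens), read by fluorescence and Amplex Red, with a stated time of 30 min; on this read-out higher numbers stand for weaker inhibition and lower numbers for stronger inhibition. Compound 1 `COc1cc(C2=NN(C(=O)c3ccccc3)C(c3ccc(Cl)cc3)C2)ccc1O` gives 6000000 nM, and compound 2 `COc1cc(C2=NN(C(=S)Nc3ccccc3)C(c3ccc(Cl)cc3)C2)ccc1O` gives 4770000 nM. Compound 2 has the lowest of the two numbers; its nearest neighbour is compound 1, and the step of a 1.3-fold lower number from compound 1 to compound 2 (0.10 log units; within the scatter) lies within the scatter, so the two values cannot be told apart.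

Compound 3 `COc1cc(C2=NN(C(=O)Oc3ccccc3)C(c3ccc(Cl)cc3)C2)ccc1O` has not yet been measured. It differs from compound 2 by a group of 9 heavy atoms (7 carbon, 2 oxygen; one six-membered aromatic ring of carbon only) in place of a group of 9 heavy atoms (7 carbon, 1 nitrogen, 1 sulfur; one six-membered aromatic ring of carbon only), on an amine nitrogen in a ring. Among the compounds with values here, the one measured step that bears on this change, made at the same amine nitrogen in the ring, is a 1.3-fold lower number from compound 1 to compound 2 (0.10 log units; within the scatter), and it stayed within the scatter. A step of no more than the scatter, in either direction, is therefore expected in this assay. Compound 3 is estimated at 5000000 nM, with a range from 2000000 nM to 15000000 nM. That estimate means an expected step of a 1.0-fold higher number from compound 2 to compound 3 (0.02 log units; within the scatter), within the scatter.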

Compound 3, inhibition constant: 5770000 nM
Compound 3: middle estimate off by 1.2-fold (0.06 log units), on the low side; the range from low to high includes it.
By their numbers in this assay, from the lowest: compounds 2, 3 and 1 (each within the scatter of the next).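

Replacing the group on the amine nitrogen in the ring, which has 1 hydrogen-bond donor, with phenoxycarbonyl, which has 0 hydrogen-bond donors, leaves the read-out within the scatter (a 1.2-fold higher number from compound 2 to compound 3 (0.08 log units; within the scatter)). Phenoxy in place of phenyl on the carbonyl carbon also gives no change that can be read (a 1.0-fold lower number from compound 1 to compound 3 (0.02 log units; within the scatter)). All three groups tried at this position therefore give values that cannot be told apart, whether the atom joining the carbonyl to the aromatic ring is absent or is an oxygen. Nothing available explains why these values stay together.

The compounds shown leave open whether a group without an aromatic ring at this nitrogen, such as acetyl or a longer alkyl chain, would move the number beyond the scatter. They also leave open what a pyridine ring would do in place of the 4-chlorophenyl group.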